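A few compounds are considered here, and "the series" means these few. Any claim that something is new, unique, unknown or untested is made for them only; others in the source may bear on it.

Working notes on the series in an ADME assay on MRC5 cells (Homo sapiens) for inhibition, read by MTT assay, with a stated time of 72 h; on this read-out higher numbers stand for weaker inhibition and lower numbers for stronger inhibition:

- compound 1 `O=C(OCCCCO)OCCc1ccc(OCc2ccccc2)c(OCc2ccccc2)c1`: "not determined" (no result reported)
- compound 2 `O=C(OCCCCCCCCO)OCCc1ccc(O)c(O)c1`: > 50000 nM
- compound 3 `CCCCCCOC(=O)OCCc1ccc(OCc2ccccc2)c(OCc2ccccc2)c1`: "not determined" (no result reported)

Within the data shown here, compound 2 is the only compound here with a reported result, and that result is a limit of the assay, not a number. The position is summed up by the limit of > 50000 nM in this assay, at which 1 of the 3 values shown sits. Among the measured compounds shown here, compounds 1 and 3 have no result, so there is no measured step between compounds to work from.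

The next compound is compound 4 `CCCCCCCCOC(=O)OCCc1ccc(O)c(O)c1`, still to be measured in this assay. Its change from compound 2 is hydrogen in place of hydroxy on a saturated chain carbon, eight bonds along the chain from an oxygen next to a carbonyl group, which can also be read as hydroxymethyl to methyl.

The only anchor for an expectation is compound 2, with > 50000 nM, a limit and not a number. A modest shift toward stronger inhibition is expected, though with little support, and a result reported only as a limit remains quite possible. The expected step of an at least 1.6-fold lower number from compound 2 to compound 4 (0.22 log units; that floor lies within the scatter) is an estimate of that shift. For compound 4 the estimated value is 30000 nM, with an expected range of 9000 nM to 50000 nM.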

Compound 4, half-maximal inhibitory concentration: 37900 nM
Estimate against measurement, compound 4: 1.3-fold (0.10 log units) below; low and high end bracket the measured number.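

In this assay, hydrogen in place of hydroxy on a saturated chain carbon, eight bonds along the chain from an oxygen next to a carbonyl group, gives the series its first single number and its first readable step: an at least 1.3-fold lower number from compound 2 to compound 4 (0.12 log units; that floor lies within the scatter). As far as these compounds go, compound 4 therefore shows that a chain without the terminal hydroxy still gives a value that can be read in this assay, while the size of the change remains open, since only a floor is printed and that floor does not clear the usual scatter. The step stays a floor and not a measured size because compound 2 is held at a limit and not at a number: the limit of > 50000 nM in this assay, at which 1 of the 4 values shown sits.

The compounds shown leave open whether an amine or a carboxylic acid at the end of the chain, or a longer chain ending in methyl, would give a value different from that of compound 4. Compounds 1 and 3 offer no value, so no comparison can be drawn from them.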